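Imidazolylmethyl anilines and ethers as adrenergic receptor agonists

This account rests on a few compounds, and the source may have more. Where it says the series, first, only, none or still open, it means among the compounds named here.

Measured so far:
compound 1, `CS(=O)(=O)c1ccccc1NCc1c[nH]cn1`, 97%
compound 2, `c1ccc(-c2ccno2)c(OCc2c[nH]cn2)c1`, 91%

In a functional assay for activation of Alpha-1A adrenergic receptor (Homo sapiens) (on this read-out lower numbers stand for smaller maximal responses and higher numbers for larger maximal responses), compound 1 gives 97% and compound 2 gives 91%; the two values lie within the usual scatter of each other, so neither stands apart. Compound 3, `c1ccc(-c2cnco2)c(NCc2c[nH]cn2)c1`, is not yet measured in this assay. It differs from compound 1 by 1,3-oxazol-5-yl in place of methylsulfonyl on an aromatic carbon. Within the data shown here, no measured pair isolates this change; compound 2, which also carries a five-membered aromatic ring in that place, shows a similarly large response. The step of a number 7 percentage points lower from compound 1 to compound 3 (within the scatter) is therefore expected to stay within the scatter. For compound 3 the estimated maximum is 90%, expected between 72% and 105%.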

Compound 3, largest response reached (reported as maximum), in percent of the reference or control that the assay uses: 120%
Beside the measured number, compound 3's estimate is 30 percentage points below it; measured number outside the range, above it.
By their numbers in this assay, from the lowest: compounds 2 and 1 (each within the scatter of the next); then compound 3.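

In this assay, the group on this aromatic carbon clearly affects the maximal response: 1,3-oxazol-5-yl in place of methylsulfonyl gives a number 23 percentage points higher from compound 1 to compound 3 (beyond the scatter), a difference that compounds 1 and 2 could not reveal. Both groups count the same hydrogen-bond donors and acceptors, so those counts do not separate them. No available evidence accounts for the step. Compound 2 differs from compound 3 in more than one place, so it cannot show whether the gain is specific to 1,3-oxazol-5-yl. On these data alone, the response with a dimethylamino group or a carboxylic acid at this carbon remains open.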